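A Fluoro Added to the Lowest-Number Compound

The compounds below may be only part of what the source reports. "The series", "measured", "known", "first", "only" and "open" are said of these compounds alone.

Measured in a functional assay on KB cells (Homo sapiens) for antiproliferative activity, read by sulforhodamine B assay, with a stated time of 48 h; on this read-out higher numbers stand for weaker inhibition of growth and lower numbers for stronger inhibition of growth:
- compound 1 `COc1ccc(S(=O)(=O)Nc2ccccc2CCc2ccc(C(=O)Nc3ccccc3N)cc2)cc1`: 23 nM
- compound 2 `Nc1ccccc1NC(=O)c1ccc(CCc2ccccc2NS(=O)(=O)c2ccc(Cl)cc2)cc1`: 448 nM
- compound 3 `Nc1ccccc1NC(=O)c1ccc(CCc2ccccc2NS(=O)(=O)c2ccc(Br)cc2)cc1`: 124 nM

Compound 1 has the lowest number of the three, so it inhibits growth most strongly. Compound 4 `COc1ccc(S(=O)(=O)Nc2ccccc2CCc2ccc(C(=O)Nc3cc(F)ccc3N)cc2)cc1` alters it in one place: fluoro in place of hydrogen on an aromatic carbon, with fluoro in place of hydrogen, turning 2-aminophenyl into 2-amino-5-fluorophenyl. The measured steps swap groups elsewhere in the molecule: a 19-fold higher number from compound 1 to compound 2 (1.29 log units; beyond the scatter), which is large, then a 5.4-fold higher number from compound 1 to compound 3 (0.73 log units; beyond the scatter) and a 3.6-fold lower number from compound 2 to compound 3 (0.56 log units; beyond the scatter), both modest. They show that one aromatic substituent can matter, but none touches the 2-aminophenyl group, so they bear only loosely here. In this assay, a slightly higher number is expected, with no step beyond the scatter: an estimated 1.5-fold higher number from compound 1 to compound 4 (0.18 log units; within the scatter). For compound 4 the expected value is 35 nM, with an estimated range of 12 nM to 105 nM.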

Compound 4, concentration for 50% growth inhibition: 66 nM
For compound 4 the middle estimate is 1.9-fold (0.28 log units) below the measured one; the measured number falls inside the stated range.
By their numbers in this assay, from the lowest: compound 1; then compounds 4 and 3 (each within the scatter of the next); then compound 2.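

In this assay, fluoro in place of hydrogen para to the amino group gives a 2.9-fold higher number from compound 1 to compound 4 (0.46 log units; beyond the scatter), so this change weakens growth inhibition beyond the scatter. Going by these compounds alone, this is the first look at the 2-aminophenyl group, which stays the same across the earlier compounds, and it shows that even 1 added heavy atom there can shift the number. Nothing available explains this step. On these data alone, whether a methyl, a hydroxyl or a nitrile at this spot would act like fluoro remains open. So does whether fluoro has the same effect when chloro or bromo replaces methoxy.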